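A few compounds are considered here, and "the series" means these few. Any claim that something is new, unique, unknown or untested is made for them only; others in the source may bear on it.

Of the compounds shown here, two of one shared core have been measured in a functional assay on HeLa cells for antagonist activity at 5-hydroxytryptamine receptor 6 (Homo sapiens), read by cAMP accumulation and immunoassay; on this read-out lower numbers stand for smaller maximal responses and higher numbers for larger maximal responses. Compound 1 `CN1CCC(n2cc(S(=O)(=O)c3cccc(Cl)c3)c3cccnc32)C1` gives 85% in this assay . Compound 2 `CCN1CCC(n2cc(S(=O)(=O)c3cccc(F)c3)c3cccnc32)C1` gives 89% in this assay , and these two values lie within the usual scatter of each other, so nothing separates them on the numbers shown.

Compound 3 `CCN1CCC(n2cc(S(=O)(=O)c3cccc(Cl)c3)c3cccnc32)C1` has not yet been measured. Compared with compound 2 it differs in one place: chloro in place of fluoro on an aromatic carbon. Compound 1 already carries a chloro group on the same ring and gives 85%, a value hardly apart from that of compound 2.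

Because compound 1 gives 85% with this same chloro group, the expected step from compound 2 to compound 3 in this assay is a number 3 percentage points lower from compound 2 to compound 3 (within the scatter), which would not stand out from the scatter. Compound 3 is therefore estimated to give 86% in this assay , with a range from 76% to 96%.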

Compound 3, largest response reached (reported as percent of maximum), in percent of the reference or control that the assay uses: 93%
Compound 3: the middle estimate sits 7 percentage points below what was measured, and the stated range covers the measured number.
By their numbers in this assay, from the lowest: compounds 1, 2 and 3 (each within the scatter of the next).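

With everything else held the same, the change from 3-fluorophenyl to 3-chlorophenyl gives a number 4 percentage points higher from compound 2 to compound 3 (within the scatter) in this assay, so this position now has its first single-change comparison, and on these numbers the two halogens cannot be told apart. Within the data shown here, compound 3 also gives the first single-change comparison at the other end of the molecule: methyl in place of hydrogen on the saturated chain carbon bound to the ring amine nitrogen gives a number 8 percentage points higher from compound 1 to compound 3 (within the scatter), and these two compounds cannot be told apart either. Nothing available explains either step.

The compounds shown leave open what a methoxy group, a nitrile or an amine would give on the aromatic ring in place of the halogen. They also leave open whether a longer chain, such as propyl, on the ring nitrogen would move the response beyond the scatter.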